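A few compounds are considered here, and "the series" means these few. Any claim that something is new, unique, unknown or untested is made for them only; others in the source may bear on it.

Among the measured compounds shown here, in a functional assay on WM 266-4 cells (Homo sapiens) for antiproliferative activity, read by MTT assay, with a stated time of 24 h (a higher number here means a weaker inhibitor of growth, a lower number a stronger inhibitor of growth), compound 1 `O=C(c1cncc(Br)c1)N1N=C(c2ccc(Cl)cc2)CC1c1ccc(Cl)cc1` gives 6090 nM and compound 2 `O=C(c1ccc(Cl)nc1)N1N=C(c2ccc(Cl)cc2)CC1c1ccc(Cl)cc1` gives 9890 nM, so compound 2 stands within the usual scatter of the only other measured compound. Compound 3 `O=C(c1cccnc1Cl)N1N=C(c2ccc(Cl)cc2)CC1c1ccc(Cl)cc1` has 2-chloropyridin-3-yl in place of 6-chloropyridin-3-yl on a carbonyl carbon. For the measured compounds named here, only one measured step bears on this change, a 1.6-fold higher number from compound 1 to compound 2 (0.21 log units; within the scatter), which also exchanges one halogen-bearing pyridinyl group for another on that carbonyl carbon. One step is thin evidence, but no change beyond the scatter is expected in this assay. The expected step is a 1.2-fold lower number from compound 2 to compound 3 (0.09 log units; within the scatter). Compound 3 is estimated at 8000 nM, with a range of 3000 nM to 20000 nM.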

Compound 3, concentration for 50% growth inhibition: 3580 nM
The estimate for compound 3 lay 2.2-fold (0.35 log units) above the measured number; the measured number falls inside the stated range.
By their numbers in this assay, from the lowest: compounds 3, 1 and 2 (each within the scatter of the next, the first and the last beyond it).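

Among the compounds shown here, on a carbonyl carbon, 2-chloropyridin-3-yl in place of 6-chloropyridin-3-yl gives a 2.8-fold lower number from compound 2 to compound 3 (0.44 log units; beyond the scatter) in this assay and is the first step here beyond the scatter, a modest one, which shows that joining the same atoms differently can alter the reading. By contrast, 2-chloropyridin-3-yl in place of 5-bromopyridin-3-yl gives a 1.7-fold lower number from compound 1 to compound 3 (0.23 log units; within the scatter) and so separates neither compound from the other. No measurement here accounts for the difference between these steps. Still open, as far as these compounds go, is how an amine or a methoxy group in place of the chlorine of 2-chloropyridin-3-yl would read.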